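From a Sulfonyl Carbamate to a Trifluoromethylbenzoate

The source may hold more compounds than are shown below. What is called first, only, known or untested is meant among the compounds shown, and "the series" means these compounds.

Compound 1 `CC1=CC[C@H]2[C@H](CC[C@]2(C)O)C(C)(C)[C@@H]1CC[C@H]1[C@]2(C)CC[C@H](OCc3ccccc3)C(C)(C)O[C@H]2CC[C@@]1(C)O` and compound 2 `CC1=CC[C@H]2[C@H](CC[C@]2(C)O)C(C)(C)[C@@H]1CC[C@H]1[C@]2(C)CC[C@H](OC(=O)NS(=O)(=O)c3ccc(C)cc3)C(C)(C)O[C@H]2CC[C@@]1(C)O` share the same core and differ only in what is attached to one oxygen of that core. In a functional assay on MCF7 cells (Homo sapiens) for antiproliferative activity, read by MTT assay, with a stated time of 72 h (a higher number here means a weaker inhibitor, a lower number a stronger inhibitor), compound 1 gives > 50000 nM, which is a limit of the assay rather than a number. Compound 2 also reaches only a limit in this assay, at > 50000 nM. Compound 2 therefore stands exactly where the other value stands, since (the limit of > 50000 nM in this assay, at which 2 of the 2 values shown sit), and no order between the two can be read.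

Compound 3 `CC1=CC[C@H]2[C@H](CC[C@]2(C)O)C(C)(C)[C@@H]1CC[C@H]1[C@]2(C)CC[C@H](OC(=O)c3cccc(C(F)(F)F)c3)C(C)(C)O[C@H]2CC[C@@]1(C)O` is the next member, differing from compound 2 by 3-(trifluoromethyl)phenyl in place of ((4-methylphenyl)sulfonyl)amino on a carbonyl carbon. Among the compounds with values here, no measured step between compounds of this kind is available, so the size of this change cannot be taken from the data. Compound 3 is expected to give about 60000 nM in this assay, between 20000 nM and 200000 nM. That estimate corresponds to a step that the limit leaves unreadable from compound 2 to compound 3, which is expected to stay within the scatter.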

Compound 3, half-maximal inhibitory concentration: 37900 nM
For compound 3 the middle estimate is 1.6-fold (0.20 log units) above the measured one, within the range that was stated.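

In this assay, within the data shown here, compound 3 gives 37900 nM, the only number among the three compounds, so a group on this oxygen can give a reading inside the range of the assay. That reading comes with a carbonyl carbon bearing 3-(trifluoromethyl)phenyl, in contrast to the benzyl of compound 1 and the ((4-methylphenyl)sulfonyl)amino of compound 2. The changes amount to an at least 1.3-fold lower number from compound 2 to compound 3 (0.12 log units; that floor lies within the scatter) and an at least 1.3-fold lower number from compound 1 to compound 3 (0.12 log units; that floor lies within the scatter), and their full size cannot be read, because compound 1 and compound 2 reach only a limit of the assay: the limit of > 50000 nM in this assay, at which 2 of the 3 values shown sit.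

The compounds shown leave open whether the trifluoromethyl group contributes to this reading or the benzoyl carbonyl alone accounts for it. An unsubstituted benzoate, or one carrying a nitrile or a carboxylic acid in place of the trifluoromethyl group, would separate these two parts.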